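This account rests on a few compounds, and the source may have more. Where it says the series, first, only, none or still open, it means among the compounds named here.

Compound 3 `CCc1ccc(C(=O)Nc2cccc(-c3oc4cc(-c5ccc(F)cc5)ccc4c(=O)c3O)c2)cc1` gives 18500 nM in a functional assay on A549 cells (Homo sapiens) for antiproliferative activity, read by CCK-8 assay, with a stated time of 72 h (a lower number here means a stronger inhibitor, a higher number a weaker inhibitor), the highest of the three numbers in hand. Compound 1 `O=C(Nc1cccc(-c2oc3cc(-c4ccc(F)cc4)ccc3c(=O)c2O)c1)c1ccc(F)cc1` gives 6930 nM and compound 2 `COc1cccc(C(=O)Nc2cccc(-c3oc4cc(-c5ccc(F)cc5)ccc4c(=O)c3O)c2)c1` gives 10800 nM. Of the steps among these, a 2.7-fold higher number from compound 1 to compound 3 (0.43 log units; beyond the scatter) lies beyond the scatter, while a 1.6-fold higher number from compound 1 to compound 2 (0.19 log units; within the scatter) and a 1.7-fold higher number from compound 2 to compound 3 (0.23 log units; within the scatter) both stay within it.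

Compound 4 `Cc1cc(C(=O)Nc2cccc(-c3oc4cc(-c5ccc(F)cc5)ccc4c(=O)c3O)c2)ccc1F` differs from compound 3 by 4-fluoro-3-methylphenyl in place of 4-ethylphenyl on a carbonyl carbon. The ring that enters carries the fluoro found in compound 1 together with a methyl, so the measured step that bears most directly on this change is a 2.7-fold higher number from compound 1 to compound 3 (0.43 log units; beyond the scatter), read in the reverse direction; the step of a 1.7-fold higher number from compound 2 to compound 3 (0.23 log units; within the scatter) shows that another exchange of the ring on the carbonyl carbon stayed within the scatter. A move back toward the number of compound 1 is therefore expected, of modest size, a 1.9-fold lower number from compound 3 to compound 4 (0.29 log units; within the scatter). Compound 4 is expected to give about 9500 nM in this assay, with a range from 4000 nM to 22000 nM.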

Compound 4, half-maximal inhibitory concentration: 11500 nM
Beside the measured number, compound 4's estimate is 1.2-fold (0.08 log units) below it, within the range that was stated.
By their numbers in this assay, from the lowest: compounds 1, 2, 4 and 3 (each within the scatter of the next, the first and the last beyond it).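

Among these compounds, in (this assay), the added methyl on the ring on the carbonyl carbon stays within the scatter (a 1.7-fold higher number from compound 1 to compound 4 (0.22 log units; within the scatter)), so this ring accepts a methyl alongside its fluoro with no step that can be told from repeat measurement. The 4-fluoro-3-methylphenyl ring also cannot be separated from 4-ethylphenyl (a 1.6-fold lower number from compound 3 to compound 4 (0.21 log units; within the scatter)) or from 3-methoxyphenyl (a 1.1-fold higher number from compound 2 to compound 4 (0.03 log units; within the scatter)), which leaves the step from compound 1 to compound 3 as the only one beyond the scatter. Nothing measured here accounts for these numbers.

Still open, from the compounds shown here alone, is whether an amine or a carboxylic acid on this ring, or a chain longer than ethyl, would shift the number beyond the scatter from that of compound 1. Also open, going by these compounds, is whether the other ring of the shared core tolerates exchange to the same degree.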